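A few compounds are considered here, and "the series" means these few. Any claim that something is new, unique, unknown or untested is made for them only; others in the source may bear on it.

Compound 1 `O=C(CSc1nnnn1-c1cccc2ccccc12)N/N=C/c1ccc(Cl)cc1`: in an ADME assay on MT4 cells (Homo sapiens) for cytotoxicity, read by MTT assay (on this read-out higher numbers stand for lower toxicity in this test and lower numbers for higher toxicity in this test), compound 1 gives only an assay limit, > 295000 nM.
Compound 2 `O=C(CSc1nnnn1-c1cccc2ccccc12)N/N=C/c1ccc(F)cc1`: in this assay compound 2 likewise gives only an assay limit, > 307000 nM.
Compound 3 `O=C(CSc1nnnn1-c1cccc2ccccc12)N/N=C/c1ccccc1O`: in this assay compound 3 gives 4850 nM.

Compound 2 thus stands at one of the two limits, and compound 1 at the other, so the step between them, a step that the two limits leave unreadable from compound 1 to compound 2, cannot be read (the limit of > 295000 nM in this assay, at which 1 of the 3 values shown sits; (the limit of > 307000 nM in this assay, at which 1 of the 3 values shown sits)). Within the data shown here, compound 3 is the only compound with a true number and sits far below both limits.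

Compound 4 `O=C(CSc1nnnn1-c1cccc2ccccc12)N/N=C/c1cccc(O)c1` is not yet measured. It differs from compound 2 in one place: 3-hydroxyphenyl in place of 4-fluorophenyl on a carbon with a double bond to nitrogen. Among the measured compounds shown here, two measured steps bear on this change, since each also puts a hydroxyphenyl in place of a halophenyl on the same carbon: an at least 63-fold lower number from compound 2 to compound 3 (1.80 log units; beyond the scatter) and an at least 60-fold lower number from compound 1 to compound 3 (1.78 log units; beyond the scatter). Both of those steps, however, concern 2-hydroxyphenyl, whereas compound 4 carries 3-hydroxyphenyl, so how fully the drop carries over is uncertain. For the measured compounds named here, a clear downward step is nonetheless expected, an at least 5.1-fold lower number from compound 2 to compound 4 (0.70 log units; beyond the scatter), possibly smaller than the one to compound 3. Compound 4 is therefore estimated at 60000 nM, with a range from 5000 nM to 300000 nM.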

Compound 4, half-maximal cytotoxic concentration: 169000 nM
For compound 4 the middle estimate is 2.8-fold (0.45 log units) below the measured one; measured number inside the range.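

In this assay, 3-hydroxyphenyl in place of 2-hydroxyphenyl on a carbon with a double bond to nitrogen gives a 35-fold higher number from compound 3 to compound 4 (1.54 log units; beyond the scatter), so the large drop seen with compound 3 cannot be credited to a hydroxyphenyl group as such: it belongs to 2-hydroxyphenyl among the compounds shown. Against the two halophenyl compounds, the 3-hydroxyphenyl group gives only an at least 1.8-fold lower number from compound 2 to compound 4 (0.25 log units; that floor lies within the scatter) and an at least 1.7-fold lower number from compound 1 to compound 4 (0.24 log units; that floor lies within the scatter), and with both floors within the scatter, neither step establishes a real drop, though either true step could be larger. The floor of the first step is set by the assay limit of compound 2: the limit of > 307000 nM in this assay, at which 1 of the 4 values shown sits.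

From the compounds shown here alone, how far compound 4 truly lies from compound 1 and compound 2 stays open, as does whether the low number of compound 3 needs the hydroxyl group itself. An amine or a methoxy group in place of that hydroxyl on the same phenyl ring would be needed to tell whether the number stays low.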